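The compounds below may be only part of what the source reports. "The series", "measured", "known", "first", "only" and "open" are said of these compounds alone.

Among the measured compounds shown here, compound 2, `Fc1ccc(-c2ccc(-c3ccc(-c4nc5ccccc5[nH]4)cc3)cc2)cc1`, is one of only two compounds measured in a functional assay on ZR-75-1 cells (Homo sapiens) for inhibition, read by sulforhodamine B assay; a lower number here means a stronger inhibitor of growth, a higher number a weaker inhibitor of growth. Compound 2 gives 100000 nM, the higher of the two numbers. The other, compound 1, `Cc1ccc2[nH]c(-c3ccc(-c4ccc(-c5cccc(Cl)c5)cc4)cc3)nc2c1`, gives 3450 nM in this assay, and the two values stand well apart, beyond the usual scatter of repeated measurements. For the measured compounds named here, no pair of measured compounds differs in just one place, so the effect of any single change on this read-out is not yet known from direct comparison.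

Compound 3, `COc1ccc(-c2ccc(-c3ccc(-c4nc5ccccc5[nH]4)cc3)cc2)cc1OC`, has not yet been measured in this assay. It differs from compound 2 in one place: 3,4-dimethoxyphenyl in place of 4-fluorophenyl on an aromatic carbon. Going by the values given here, with no measured step of this kind to lean on, the size of the change is uncertain; a move toward a lower number is expected, given that compound 2 gives 100000 nM, the highest value seen so far, but a step no larger than the scatter would not be surprising. Compound 3 is expected to give about 30000 nM in this assay, within an estimated range from 6000 nM to 100000 nM. That estimate means a step of a 3.3-fold lower number from compound 2 to compound 3 (0.52 log units; beyond the scatter).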

Compound 3, concentration for 50% growth inhibition: 39700 nM
Compound 3: middle estimate off by 1.3-fold (0.12 log units), on the low side; measured number inside the range.
By their numbers in this assay, from the lowest: compound 1; then compound 3; then compound 2.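

In this assay, among the compounds shown here, the first direct comparison in this set is a 2.5-fold lower number from compound 2 to compound 3 (0.40 log units; beyond the scatter) and it comes from placing 3,4-dimethoxyphenyl where 4-fluorophenyl stood, on an aromatic carbon para to a large group. The group at this position therefore does affect the read-out, if only modestly. The change adds heavy atoms and two hydrogen-bond acceptors, and the number moves toward stronger growth inhibition rather than weaker. No measurement in hand bears on what lies behind this step.

A single step cannot separate what is lost with the fluorine from what is gained with the two methoxy groups, and a single methoxy group, an amine or a carboxylic acid at this position could give quite a different number. Going by these compounds, compound 1 differs from compound 2 and compound 3 in more than one place, so its lower number cannot be tied to this position, and whether the same change would help on the core of compound 1 also remains unknown.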